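The source may report more compounds than this note shows. Statements on the series, on what has been measured and on what is new or still open speak of the compounds shown alone.

Measured compounds:
compound 1 `CCC(=O)N1N=C(c2ccccc2)CC1c1ccc(C)cc1` — 75900 nM
compound 2 `CCC(=O)N1N=C(c2ccc(F)cc2)CC1c1ccc(C)cc1` — 10000 nM
compound 3 `CCC(=O)N1N=C(c2ccc(C)cc2)CC1c1ccc(C)cc1` — 100000 nM

All three values come from an assay on isolated protein for inhibition of Amine oxidase [flavin-containing] A (Bos taurus); on this read-out higher numbers stand for weaker inhibition and lower numbers for stronger inhibition. Compound 3 gives the highest number of the three; its nearest neighbour is compound 1, separated by a 1.3-fold higher number from compound 1 to compound 3 (0.12 log units; within the scatter), and the furthest is compound 2, separated by a 10-fold higher number from compound 2 to compound 3 (1.00 log units; beyond the scatter). Within the data shown here, the only step that passes beyond the scatter on this read-out is a 7.6-fold lower number from compound 1 to compound 2 (0.88 log units; beyond the scatter), a fluoro in place of hydrogen on an aromatic carbon; the methyl in place of hydrogen on an aromatic carbon leaves the number where it was.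

Compound 4 `CCC(=O)N1N=C(c2ccc(C)cc2)CC1c1ccc(OC)cc1` is not yet measured. Its difference from compound 3 is methoxy in place of methyl on an aromatic carbon. Among the measured compounds shown here, none of the measured steps concerns a methyl to methoxy exchange, and none touches a methoxy at all; they only show that a hydrogen, methyl or fluoro exchange on an aromatic carbon can move the number by nothing or by a modest amount. On that basis no step beyond the scatter is firmly expected for compound 4 in this assay, with a slight lean towards a lower number.

The estimate for compound 4 in this assay is 60000 nM, expected to fall between 15000 nM and 200000 nM. This estimate corresponds to an expected step of a 1.7-fold lower number from compound 3 to compound 4 (0.22 log units; within the scatter).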

Compound 4, half-maximal inhibitory concentration: 74100 nM
Compound 4: the middle estimate sits 1.2-fold (0.09 log units) below what was measured; the range from low to high includes it.
By their numbers in this assay, from the lowest: compound 2; then compounds 4, 1 and 3 (each within the scatter of the next).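

Among these compounds, compound 1, compound 2 and compound 3 all carry the 4-methylphenyl group and vary only the other aromatic ring, so compound 4 gives the first reading at this position. In this assay, the change from 4-methylphenyl to 4-methoxyphenyl gives a 1.3-fold lower number from compound 3 to compound 4 (0.13 log units; within the scatter), so methoxy and methyl are not separated here, even though methoxy adds one heavy atom and one hydrogen-bond acceptor. Nothing available explains this flat step, and a single exchange cannot show whether the position is insensitive in general or whether these two groups merely happen to read alike.

The series leaves open whether an amine, a carboxylic acid, a longer chain such as ethoxy, or a plain hydrogen at this position would move the number beyond the scatter. It also leaves open whether the step seen with fluoro on the other ring, a 7.6-fold lower number from compound 1 to compound 2 (0.88 log units; beyond the scatter), would carry over to a compound holding the 4-methoxyphenyl group, or whether fluoro at the present position would give a comparable step.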